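The source may hold more compounds than are shown below. What is called first, only, known or untested is meant among the compounds shown, and "the series" means these compounds.

Compound 1 `CC(=O)O[C@@H]1OC(=O)[C@](C)(C(C)=O)[C@@H]1C` gives 7000 nM in a functional assay on DA-3 cells for cytotoxicity against DA-3 cell line (Mus musculus), read by MTT assay; on this read-out higher numbers stand for weaker inhibition and lower numbers for stronger inhibition. Compound 2 `CC(=O)[C@@]1(C)C(=O)O[C@@H](OC(=O)c2ccccc2)[C@H]1C` gives 1000 nM in this assay; the change phenyl in place of methyl on a carbonyl carbon made the step of a 7.0-fold lower number from compound 1 to compound 2 (0.85 log units; beyond the scatter). Compound 3 `CC(=O)O[C@@H]1OC(=O)[C@@](C)(C(C)=O)[C@@H]1C` gives 9000 nM in this assay; its core differs from the core of compound 1 by the two compounds have the same atoms and bonds and differ only in configuration as drawn: 1 of 3 stereo elements differ; a stereocentre at a saturated ring carbon is drawn S in compound 1 and R in compound 3, and the step of a 1.3-fold higher number from compound 1 to compound 3 (0.11 log units; within the scatter) stays within the scatter because of the fact that compounds 1 and 3 differ only in the configuration as drawn. Compound 4 `CC(=O)O[C@@H]1OC(=O)[C@@](C)(C(=O)c2ccccc2)[C@@H]1C` is not yet measured. The change from compound 3 to compound 4 is phenyl in place of methyl on a carbonyl carbon; it is the same kind of change as from compound 1 to compound 2, not the same, since the place differs: the carbonyl carbon's other neighbour is a saturated ring carbon rather than oxygen next to a carbonyl group. The expected step here, resting on the earlier step of a 7.0-fold lower number from compound 1 to compound 2 (0.85 log units; beyond the scatter) at a different place, is a 2.6-fold lower number from compound 3 to compound 4 (0.41 log units; beyond the scatter), somewhat smaller. Compound 4 is estimated at 3500 nM, from 1000 nM to 10000 nM.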

Compound 4, half-maximal inhibitory concentration: 15000 nM
For compound 4 the middle estimate is 4.3-fold (0.63 log units) below the measured one; measured number outside the range, above it.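

In this assay phenyl in place of methyl on a carbonyl carbon gives a 1.7-fold higher number from compound 3 to compound 4 (0.22 log units; within the scatter) and so brings no gain at this place, whereas the earlier step does not carry over to it: the same change on two cores in this assay, a 7.0-fold lower number (0.85 log units; beyond the scatter) from compound 1 to compound 2 and a 1.7-fold higher number (0.22 log units; within the scatter) from compound 3 to compound 4, 12-fold (1.07 log units) apart, beyond the scatter of two such steps. The change therefore cannot be treated as transferable between these two places in the series. These two steps do not show what lies behind the gap, and they cannot separate the place of the change from the configuration as drawn.

Still open, as far as these compounds go, is how phenyl at this place behaves on the core of compound 1. Also open, from the compounds shown here alone, is whether an amine or a longer chain on this carbonyl carbon would move the number beyond the scatter.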